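From Methoxy to Chloro on the Shared Core

A few compounds are considered here, and "the series" means these few. Any claim that something is new, unique, unknown or untested is made for them only; others in the source may bear on it.

Within the data shown here, compound 2 `COc1ccccc1S(=O)(=O)/C=C/c1cccnc1OC` stands lowest of the two numbers measured so far. In an ADME assay on BV-2 cells (Mus musculus) for cytotoxicity, with a stated time of 24 h, tested at 50 uM (on this read-out lower numbers stand for a stronger effect and higher numbers for a weaker effect at the one concentration tested), compound 2 gives 81.9%, while compound 1 `COc1ccccc1S(=O)(=O)/C=C/c1cccnc1` gives 92%. Among the measured compounds shown here, the single measured step, a number 10.1 percentage points lower from compound 1 to compound 2 (beyond the scatter), is a methoxy in place of hydrogen on an aromatic carbon, and it lowered the number by a modest amount that is nevertheless beyond the scatter.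

Compound 3 `COc1ccccc1S(=O)(=O)/C=C/c1cccnc1Cl` has not been measured. It differs from compound 2 by chloro in place of methoxy on an aromatic carbon. For the measured compounds named here, no measured step shows chloro entering or methoxy leaving, so the change cannot be matched to any step already seen. Going by the values given here, the one step on record is modest, so a similarly modest movement, or none beyond the scatter, seems the most reasonable guess. Compound 3 is expected to give about 85%, with a range from 68% to 100%, a step of a number 3.1 percentage points higher from compound 2 to compound 3 (within the scatter) that is expected to stay within the scatter.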

Compound 3, a percentage reported as activity, at one concentration (the size of the read-out at that concentration, not a potency): 87.5%
Beside the measured number, compound 3's estimate is 2.5 percentage points below it; the range from low to high includes it.
By their numbers in this assay, from the lowest: compounds 2, 3 and 1 (each within the scatter of the next, the first and the last beyond it).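

In this assay, the site next to the ring nitrogen now carries a third substituent on record, and the swap of methoxy for chloro gives a number 5.6 percentage points higher from compound 2 to compound 3 (within the scatter) on the shared core. Chloro in place of hydrogen at the same site gives a number 4.5 percentage points lower from compound 1 to compound 3 (within the scatter) and so also stays within the usual variation, which means that compound 3 cannot be separated from either neighbour, although compound 1 and compound 2 are separated from each other. Nothing available accounts for these numbers.

Going by these compounds, it remains open whether an amine or a carboxylic acid at this site would give a number clearly apart from that of compound 3. Also open, on these data alone, is whether chloro would behave the same way on another carbon of this ring.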